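A few compounds are considered here, and "the series" means these few. Any claim that something is new, unique, unknown or untested is made for them only; others in the source may bear on it.

Among the compounds with values here, compound 1 `CN(C)/C(=N/CCCCn1nc(-c2ccccc2)ccc1=O)NC#N` gives 30.3 mg/kg in a functional assay on the whole organism (stomach) with Rattus norvegicus as the target (on this read-out higher numbers stand for an effect only at larger amounts of compound and lower numbers for an effect already at smaller amounts), and it stands apart in that it is the only compound among the three measured for which a number, rather than a limit, is known. Compound 2 `O=c1ccc(-c2ccccc2)nn1CCCC/N=C(\S)Nc1cccc(F)c1` reaches only a limit of this assay, > 100 mg/kg. Compound 3 `C/N=C(/NC#N)NCCCCn1nc(-c2ccccc2)c(C)cc1=O` likewise stops at a limit of this assay, > 100 mg/kg. In this assay, within the data shown here, then, the limit of > 100 mg/kg in this assay, at which 2 of the 3 values shown sit, marks where two of the three measured values sit, and no pair of measured compounds differs in a single place, so no measured step can be followed.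

Compound 4 `C/N=C(\S)NCCCCn1nc(-c2ccccc2)ccc1=O` has not yet been measured in this assay. It differs from compound 1 in one place: a group of 5 heavy atoms (2 carbon, 2 nitrogen, 1 sulfur; no ring) in place of a group of 8 heavy atoms (4 carbon, 4 nitrogen; no ring), on a saturated chain carbon, four bonds along the chain from an aromatic nitrogen.

Among the measured compounds shown here, with no measured step of this kind to lean on, the expectation rests only on what the measured values show. Compound 2, which also carries a sulfur in its chain group, sits at a limit. Compound 1 gives a number. That is the only hint, and it points toward a larger dose for compound 4 rather than a smaller one. In this assay compound 4 is expected to need about 80 mg/kg, within a range from 25 mg/kg to 250 mg/kg. That estimate means a 2.6-fold higher number from compound 1 to compound 4 (0.42 log units; beyond the scatter), expected to lie beyond the scatter and toward larger doses, with a real chance that only a limit is reported.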

Compound 4, dose for half-maximal effect: 28.9 mg/kg
Compound 4: the middle estimate sits 2.8-fold (0.44 log units) above what was measured; the range from low to high includes it.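

In this assay, exchanging the group at this place, on a saturated chain carbon, four bonds along the chain from an aromatic nitrogen, amounts to a 1.0-fold lower number from compound 1 to compound 4 (0.02 log units; within the scatter), so the two compounds cannot be told apart on this read-out. Within the data shown here, this is the first single-place comparison, and it shows that the group of 8 heavy atoms (4 carbon, 4 nitrogen; no ring) can give way to the much smaller sulfur-bearing group of 5 heavy atoms (2 carbon, 2 nitrogen, 1 sulfur; no ring) while a number is still obtained, so sulfur in this group does not by itself bring a compound to the limit. Compound 2, which also carries sulfur, and compound 3 still stand at a limit rather than at a number: the limit of > 100 mg/kg in this assay, at which 2 of the 4 values shown sit.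

The compounds shown leave open whether a simple amine or a carboxylic acid at the same place would still give a number in this assay. They also leave open how a shorter or longer chain in place of the butyl chain would read with the sulfur-bearing group in place.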